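Difluorination of the Triazole Aryl in a Trifluoromethyl Series

The source may hold more compounds than are shown below. What is called first, only, known or untested is meant among the compounds shown, and "the series" means these compounds.

Of the compounds shown here, three sharing one core have been measured in a functional assay on MCF7 cells (Homo sapiens) for cytotoxicity, read by MTT assay, with a stated time of 72 h; on this read-out higher numbers stand for weaker inhibition and lower numbers for stronger inhibition. Compound 1 `Cc1c(C(=O)Nc2ccc(Oc3ccnc4[nH]ccc34)c(F)c2)nnn1-c1ccccc1` gives 350 nM. Compound 2 `Cc1c(C(=O)Nc2ccc(Oc3ccnc4[nH]ccc34)c(F)c2)nnn1-c1ccc(F)c(F)c1` gives 820 nM, and compound 3 `O=C(Nc1ccc(Oc2ccnc3[nH]ccc23)c(F)c1)c1nnn(-c2ccccc2)c1C(F)(F)F` gives 1150 nM. The step of a 3.3-fold higher number from compound 1 to compound 3 (0.52 log units; beyond the scatter) lies beyond the scatter, so compound 3 stands clearly apart from compound 1, while the values of compound 3 and compound 2 lie within the scatter of each other.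

Compound 4 `O=C(Nc1ccc(Oc2ccnc3[nH]ccc23)c(F)c1)c1nnn(-c2ccc(F)c(F)c2)c1C(F)(F)F` differs from compound 3 by 3,4-difluorophenyl in place of phenyl on an aromatic nitrogen. The same change has been seen once already, on the methyl-bearing core, as a 2.3-fold higher number from compound 1 to compound 2 (0.37 log units; beyond the scatter), a modest weakening that lay beyond the scatter. For the measured compounds named here, no measured pair shows this change on the trifluoromethyl-bearing core, so the account rests on that single precedent. Compound 4 is therefore expected to give a somewhat higher number than compound 3 in this assay, with a step of about a 2.1-fold higher number from compound 3 to compound 4 (0.32 log units; beyond the scatter) anticipated because of a 2.3-fold higher number from compound 1 to compound 2 (0.37 log units; beyond the scatter). The estimate for compound 4 is 2400 nM, within a range of 1200 nM to 5000 nM.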

Compound 4, half-maximal inhibitory concentration: 590 nM
Beside the measured number, compound 4's estimate is 4.1-fold (0.61 log units) above it; measured number below the stated range.
By their numbers in this assay, from the lowest: compounds 1, 4, 2 and 3 (each within the scatter of the next, the first and the last beyond it).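

In this assay, 3,4-difluorophenyl in place of phenyl on the aromatic nitrogen next to the ring atom that bears a trifluoromethyl group gives a 1.9-fold lower number from compound 3 to compound 4 (0.29 log units; within the scatter), so the weakening seen on the methyl-bearing core does not carry over to this core. The outcome of this change therefore depends on the core that carries it: the same change on two cores in this assay, a 2.3-fold higher number (0.37 log units; beyond the scatter) from compound 1 to compound 2 and a 1.9-fold lower number (0.29 log units; within the scatter) from compound 3 to compound 4, 4.6-fold (0.66 log units) apart, beyond the scatter of two such steps. Read the other way, trifluoromethyl in place of methyl gives a 1.4-fold lower number from compound 2 to compound 4 (0.14 log units; within the scatter) when 3,4-difluorophenyl is present, so the two changes do not simply add up: the same change on two cores in this assay, a 3.3-fold higher number (0.52 log units; beyond the scatter) from compound 1 to compound 3 and a 1.4-fold lower number (0.14 log units; within the scatter) from compound 2 to compound 4, 4.6-fold (0.66 log units) apart, beyond the scatter of two such steps.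

The compounds shown leave open whether a single fluorine on the phenyl ring would follow the same course on either core. They also leave open how an ethyl group or a chlorine on the aromatic carbon would shape the step.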